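Alkynyl nucleoside series: Vero cytotoxicity and alkyne chain length

The source may hold more compounds than are shown below. What is called first, only, known or untested is meant among the compounds shown, and "the series" means these compounds.

Measured so far:
compound 1, `CCCCCCCCCCCCC#Cc1cn([C@H]2CC[C@@H](CO)O2)c(=O)[nH]c1=O`, > 100 ug/mL
compound 2, `CCCCCCCCCCCCC#Cc1cn(C2CC(F)C(CO)O2)c(=O)[nH]c1=O`, > 100 ug/mL
Not yet measured:
compound 3, `CCCCCCCCCC#Cc1cn([C@H]2CC[C@@H](CO)O2)c(=O)[nH]c1=O`

In an ADME assay on Vero cells (Homo sapiens) for cytotoxicity against Vero (Chlorocebus sabaeus), read by MTT assay (on this read-out lower numbers stand for higher toxicity in this test and higher numbers for lower toxicity in this test), compound 1 gives > 100 ug/mL, which is a limit of the assay and not a number. In this assay compound 2 gives > 100 ug/mL, likewise a limit. The step that the two limits leave unreadable from compound 1 to compound 2 is therefore unreadable, since both ends sit at a limit; all that is known on this point is the limit of > 100 ug/mL in this assay, at which 2 of the 2 values shown sit.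

Compound 3 differs from compound 1 by hydrogen in place of propyl on a saturated chain carbon, nine bonds along the chain from a triple-bonded carbon. Among the compounds with values here, no measured step touches the alkyne chain; the single recorded step concerns the sugar only, and its size is not readable. The expectation for compound 3 can thus rest on nothing more than compound 1 sitting at the limit > 100 ug/mL in this assay. Compound 3 is expected to stay at or near that limit, with the step that the limit leaves unreadable from compound 1 to compound 3 expected to be none beyond the scatter. The estimate for compound 3 in this assay is 150 ug/mL, with a range from 70 ug/mL to 400 ug/mL, and a measurement reported only as a limit is the most likely outcome.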

Compound 3, half-maximal cytotoxic concentration: > 100 ug/mL
Compound 3 gave a limit, no number (the forecaster's own chance of this, stated with the estimate: 80%); the middle value is on the limit's open side.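

In this assay compound 3 gives > 100 ug/mL, a limit and not a number. No new step can be read between compound 1 and compound 3, as both sit at a limit: the limit of > 100 ug/mL in this assay, at which 3 of the 3 values shown sit.

The compounds shown leave open what size, if any, the shorter alkyne chain or the fluorine on the sugar has in this assay.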